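The source may report more compounds than this note shows. Statements on the series, on what has been measured and on what is new or still open speak of the compounds shown alone.

Series values in an ADME assay on HepG2 2.2.15 cells (Homo sapiens) for cytotoxicity, read by MTT assay, with stated times of 48 h and 9 days; a higher number here means that more compound is tolerated, a lower number that less compound is tolerated:
- compound 1 `COc1ccc2c(=O)c(/C=C/C(=O)Nc3cccc(C)c3)coc2c1`: 554000 nM
- compound 2 `COc1ccc2c(=O)c(/C=C/C(=O)NCc3ccc(F)cc3)coc2c1`: 133000 nM
- compound 3 `O=C(/C=C/c1coc2cc(O)ccc2c1=O)NCc1ccc(F)cc1`: 357000 nM

Compound 3 stands within the scatter of compound 1 and clearly above compound 2, the lowest of the three. Compound 4 `Cc1ccc(CNC(=O)/C=C/c2coc3cc(O)ccc3c2=O)cc1` has not yet been measured. It carries methyl in place of fluoro on an aromatic carbon, para to a large group (methyl in place of fluoro on an aromatic carbon), which turns 4-fluorobenzyl into 4-methylbenzyl.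

Going by the values given here, no measured pair isolates this exchange. The closest evidence is the change on the amide-type nitrogen, 4-fluorobenzyl in place of 3-methylphenyl, which gave a 4.2-fold lower number from compound 1 to compound 2 (0.62 log units; beyond the scatter). The other measured change, hydrogen in place of methyl on an oxygen on an aromatic ring, gave a 2.7-fold higher number from compound 2 to compound 3 (0.43 log units; beyond the scatter) and lies elsewhere in the molecule. Among the compounds with values here, both steps are modest, and the first replaces a whole group on the nitrogen, whereas the present change swaps one substituent and keeps the benzyl group. Neither step gives a direction for fluoro to methyl, so no shift beyond the scatter is expected in this assay.

The expected outcome is a 1.2-fold lower number from compound 3 to compound 4 (0.08 log units; within the scatter). For compound 4 the estimate is 300000 nM, with an expected range of 130000 nM to 650000 nM.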

Compound 4, half-maximal cytotoxic concentration: 501000 nM
Beside the measured number, compound 4's estimate is 1.7-fold (0.22 log units) below it, and the stated range covers the measured number.
By their numbers in this assay, from the lowest: compound 2; then compounds 3, 4 and 1 (each within the scatter of the next).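

In this assay, methyl in place of fluoro on an aromatic carbon, para to a large group, gives a 1.4-fold higher number from compound 3 to compound 4 (0.15 log units; within the scatter), so turning 4-fluorobenzyl into 4-methylbenzyl leaves the number within the scatter. Going by these compounds alone, this is the first pair to isolate a single substituent on the benzyl group, as the earlier steps replaced the whole group on the amide-type nitrogen or changed the substituent on an oxygen on the aromatic ring. For these two compounds, the exchange of fluoro for methyl at this position is tolerated without a shift that can be told from the scatter, but nothing measured here explains that result.

It remains open whether the same exchange would also stay within the scatter with methyl on the oxygen of the shared core, as in compound 2, since the pair shown carries hydrogen there. Going by these compounds, it is also open how far this tolerance extends to a different kind of substituent on the same aromatic carbon, such as an amine, a carboxylic acid or a longer alkyl chain.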